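The source may hold more compounds than are shown below. What is called first, only, known or untested is meant among the compounds shown, and "the series" means these compounds.

In a functional assay on SK-OV-3 cells (Homo sapiens) for inhibition, read by CCK-8 assay, with a stated time of 70 h (on this read-out lower numbers stand for stronger inhibition and higher numbers for weaker inhibition), compound 1 `COc1ccc(OCCOCCNC2CCCC2)cc1` gives 99100 nM, compound 2 `COc1ccc(COc2ccc(OCCOCCNC3CCCC3)cc2)cc1` gives 15700 nM and compound 3 `Nc1cccc(COc2ccc(OCCOCCNC3CCCC3)cc2)c1` gives 10800 nM. Compound 3 therefore sits level with compound 2, well under compound 1. Compound 4 `O=[N+]([O-])c1ccc(COc2ccc(OCCOCCNC3CCCC3)cc2)cc1` carries 4-nitrophenyl in place of 3-aminophenyl on the same saturated chain carbon: 4-nitrophenyl in place of 3-aminophenyl on a saturated chain carbon bound to an oxygen on an aromatic ring. Putting a substituted phenyl group in place of hydrogen mattered, with a 6.3-fold lower number from compound 1 to compound 2 (0.80 log units; beyond the scatter) and a 9.2-fold lower number from compound 1 to compound 3 (0.96 log units; beyond the scatter). Exchanging one such group for another is the closer precedent, and it gave only a 1.5-fold lower number from compound 2 to compound 3 (0.16 log units; within the scatter). Only these two groups have been compared, so the precedent is thin, and no step beyond the scatter is expected in this assay. The estimated change is a 1.3-fold higher number from compound 3 to compound 4 (0.11 log units; within the scatter). For compound 4 the expected value is 14000 nM, with an estimated range of 6000 nM to 35000 nM.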

Compound 4, half-maximal inhibitory concentration: 20300 nM
For compound 4 the middle estimate is 1.5-fold (0.16 log units) below the measured one, and the stated range covers the measured number.
By their numbers in this assay, from the lowest: compounds 3, 2 and 4 (each within the scatter of the next); then compound 1.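

In this assay, a third substituted phenyl group on this saturated chain carbon lands level with the other two, with a 1.9-fold higher number from compound 3 to compound 4 (0.27 log units; within the scatter) and a 1.3-fold higher number from compound 2 to compound 4 (0.11 log units; within the scatter) as the two steps. Even nitro in place of methoxy on the ring therefore leaves the number within the scatter, while the advantage over plain hydrogen remains, with a 4.9-fold lower number from compound 1 to compound 4 (0.69 log units; beyond the scatter) in this short series. Still open, going by these compounds, is whether a ring without aromatic character, such as cyclohexyl, or a phenyl carrying a carboxylic acid would stand apart from these three. No measurement here gives a reason for these numbers.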